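Thiophen-2-yl in Place of Pyridin-2-yl on Two Cores

A few compounds are considered here, and "the series" means these few. Any claim that something is new, unique, unknown or untested is made for them only; others in the source may bear on it.

Measured so far in a functional assay for inhibition, with Homo sapiens as the target; on this read-out higher numbers stand for weaker inhibition and lower numbers for stronger inhibition:
Compound 1 `Cc1cccc(Nc2nccc(-c3ccccn3)n2)c1` gives 700 nM.
Compound 2 `Cc1cccc(Nc2nccc(-c3cccs3)n2)c1` gives 300 nM.
Compound 3 `CC1CCN(c2ccc(Nc3nccc(-c4ccccn4)n3)cc2)CC1` gives 1900 nM.

Compound 3 shows the highest number of the three. How its core differs from the core of compound 1 is not broken down here. From compound 1 to compound 2 the change is thiophen-2-yl in place of pyridin-2-yl on an aromatic carbon, and it made the step of a 2.3-fold lower number from compound 1 to compound 2 (0.37 log units; beyond the scatter). Compound 4 `CC1CCN(c2ccc(Nc3nccc(-c4cccs4)n3)cc2)CC1` is not yet measured; from compound 3 it differs by thiophen-2-yl in place of pyridin-2-yl on an aromatic carbon. This is the same kind of change, though the surroundings are described differently: in one pair the place is meta to a group of 8 heavy atoms, in the other meta to a large group. Compound 4 is expected to give 830 nM in this assay, estimated to lie between 400 nM and 1700 nM. The expected step for compound 4 is a 2.3-fold lower number from compound 3 to compound 4 (0.36 log units; beyond the scatter), resting on the earlier step of a 2.3-fold lower number from compound 1 to compound 2 (0.37 log units; beyond the scatter).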

Compound 4, half-maximal inhibitory concentration: 400 nM
Compound 4: middle estimate off by 2.1-fold (0.32 log units), on the high side; low and high end bracket the measured number.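

Thiophen-2-yl in place of pyridin-2-yl again lowered the number in this assay, with a 4.8-fold lower number from compound 3 to compound 4 (0.68 log units; beyond the scatter). Set beside the earlier step, the two steps do not differ by more than the scatter allows: the same change on two cores in this assay, a 2.3-fold lower number (0.37 log units; beyond the scatter) from compound 1 to compound 2 and a 4.8-fold lower number (0.68 log units; beyond the scatter) from compound 3 to compound 4, 2.0-fold (0.31 log units) apart, within the scatter of two such steps. Within the data shown here, on these two cores the change therefore carries over in direction and, within the scatter, in size, but with only one pair on each core this does not show that it would carry over to any other core, and it does not show why the number falls.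

The compounds shown leave open whether phenyl in that place would go the same way. They also leave open whether an amine or a carboxylic acid on the thiophene ring would keep the lower number.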